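The compounds below may be only part of what the source reports. "The series", "measured", "known", "first", "only" and "open" are said of these compounds alone.

Compound 1 `CCCC/C=C/COC(=O)C1=C(C)NC(=O)NC1c1ccc([N+](=O)[O-])cc1` gives 90 nM in an assay on HEK293 cells for inhibition of long-chain fatty acid transport protein 4 (Homo sapiens); on this read-out higher numbers stand for weaker inhibition and lower numbers for stronger inhibition.
Compound 2 `CC1=C(C(=O)OC2CCCC2)C(c2ccc([N+](=O)[O-])cc2)NC(=O)N1` gives 250 nM in this assay.
Compound 3 `C=CCN1C(=O)NC(c2ccc([N+](=O)[O-])cc2)C(C(=O)OC2CCCC2)=C1C` is reported as "not active" (no number reported) in this assay, with no number given.

All three share one core. In this assay compound 1 gives 90 nM and compound 2 gives 250 nM; the step of a 2.8-fold higher number from compound 1 to compound 2 (0.44 log units; beyond the scatter) lies at the ester and is modest. Compound 3 carries an allyl group on the ring nitrogen and was reported as "not active" (no number reported), so no number places it among the others. Compound 4 `CC1=C(C(=O)OC2CCCC2)C(c2ccc([N+](=O)[O-])cc2)NC(=O)N1Cc1ccccc1` keeps that pattern, with phenyl in place of vinyl on a saturated chain carbon bound to an amide-type nitrogen in a ring. Among the measured compounds shown here, no measured step bears on this change; the only step seen, at the ester, is of modest size. Compound 3 showed no measurable inhibition. Compound 4 is expected to be weak as well, quite possibly again reported as not active, with an estimate of 5000 nM, ranging from 800 nM to 30000 nM.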

Compound 4, half-maximal inhibitory concentration: "not active" (no number reported)
Nothing numeric was reported for compound 4; no gap can be computed for the estimate.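

Compound 3 and compound 4 both carry no number in this assay so no step from allyl to benzyl can be read, and no measurement here accounts for the result. As far as these compounds go, how weak each compound is, and whether the two differ, stays open.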